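The source may hold more compounds than are shown below. What is called first, only, known or untested is meant among the compounds shown, and "the series" means these compounds.

Measured compounds:
compound 1, `CCOC(=O)C1=C(C)NC(C)=C(C(=O)OCC)C1c1cc(=O)cc(-c2ccccc2)o1` — 3240 nM
compound 2, `CCOC(=O)C1=C(C)NC(C)=C(C(=O)OCC)C1c1cc(=O)cc(C)o1` — 35900 nM

In an assay on isolated protein (strain albino) for inhibition of Voltage-dependent L-type calcium channel subunit alpha-1C (Cavia porcellus) (on this read-out higher numbers stand for weaker inhibition and lower numbers for stronger inhibition), compound 1 gives 3240 nM, the lower of the two numbers seen so far. Going by the values given here, the only measured step, an 11-fold higher number from compound 1 to compound 2 (1.04 log units; beyond the scatter), comes with methyl in place of phenyl on an aromatic carbon, so the phenyl-bearing compound 1 stands well apart from compound 2.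

Compound 3, `CCOC(=O)C1=C(C)NC(C)=C(C(=O)OC)C1c1cc(=O)cc(-c2ccccc2)o1`, differs from compound 1 by hydrogen in place of methyl on a saturated chain carbon bound to an oxygen next to a carbonyl group. This shortens one of the two ester chains by a single carbon and leaves the phenyl untouched. Among the compounds with values here, no measured step touches this part of the molecule; the one step known concerns the aromatic carbon, a different place, so it gives no direct guide here. A change this small is expected to move the number by a 1.1-fold higher number from compound 1 to compound 3 (0.03 log units; within the scatter), that is, not beyond the scatter. Compound 3 is therefore estimated at 3500 nM, with a range from 1500 nM to 9000 nM.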

Compound 3, half-maximal inhibitory concentration: 2030 nM
Compound 3: the middle estimate sits 1.7-fold (0.24 log units) above what was measured; low and high end bracket the measured number.
By their numbers in this assay, from the lowest: compounds 3 and 1 (each within the scatter of the next); then compound 2.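

In this assay the step from ethoxycarbonyl to methoxycarbonyl gives a 1.6-fold lower number from compound 1 to compound 3 (0.20 log units; within the scatter) and so lies within the scatter, which means compound 1 and compound 3 cannot be told apart on this read-out. Going by these compounds alone, this is the first look at the ester chain, and removing one carbon from this ethyl group leaves the number within the usual noise of the measurement, whereas the change on the aromatic carbon gave an 11-fold higher number from compound 1 to compound 2 (1.04 log units; beyond the scatter) and lay beyond it. No measurement offers an explanation for this result.

The compounds shown leave open whether a longer chain such as propyl or butyl, or a carboxylic acid, at this same ester would also leave the number within the scatter. They also leave open whether shortening the second ethyl ester would give the same result.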